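Shifting a chlorine across two related cores

This account rests on a few compounds, and the source may have more. Where it says the series, first, only, none or still open, it means among the compounds named here.

Compound 1, `Cc1cc(OCc2nc3ccccc3s2)ccc1NC(=O)Nc1ccccc1Cl`: 830 nM
Compound 2, `Cc1cc(OCc2nc3ccccc3s2)ccc1NC(=O)Nc1cccc(Cl)c1`: 160 nM
Compound 3, `O=C(Nc1ccc(OCc2nc3ccccc3s2)cc1)Nc1ccccc1Cl`: 360 nM

Of the compounds shown here, three have been measured in an assay on isolated protein for inhibition of Polyunsaturated fatty acid 5-lipoxygenase (Homo sapiens), read by HPLC, with a stated time of 10 min (on this read-out higher numbers stand for weaker inhibition and lower numbers for stronger inhibition), and a fourth, compound 4, `O=C(Nc1ccc(OCc2nc3ccccc3s2)cc1)Nc1cccc(Cl)c1`, has not. Compound 1 and compound 2 share a core and differ only in the change (3-chlorophenyl in place of 2-chlorophenyl on an amide-type nitrogen); this change gives a 5.2-fold lower number from compound 1 to compound 2 (0.71 log units; beyond the scatter). Compound 3 is built on a second core that differs from the core of compound 1 by hydrogen in place of methyl on an aromatic carbon, a change that on its own gives a 2.3-fold lower number from compound 1 to compound 3 (0.36 log units; beyond the scatter). Compound 2 and compound 3 are not linked by a single-point step, and their two values in this assay stand apart.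

Compound 4 relates to compound 3 exactly as compound 2 relates to compound 1: the change is 3-chlorophenyl in place of 2-chlorophenyl on an amide-type nitrogen, and the surroundings of the place where it is made read the same in both pairs, so it is the same change carried onto the second core. For the measured compounds named here, only one earlier instance of it exists, so how far it carries over is uncertain. Going by the values given here, compound 4 is therefore expected to show a 4.5-fold lower number from compound 3 to compound 4 (0.65 log units; beyond the scatter), a step resting on the single earlier instance a 5.2-fold lower number from compound 1 to compound 2 (0.71 log units; beyond the scatter). On that basis compound 4 is estimated at 80 nM in this assay, with a likely range from 30 nM to 250 nM.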

Compound 4, half-maximal inhibitory concentration: 170 nM
Estimate against measurement, compound 4: 2.1-fold (0.33 log units) below, within the range that was stated.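

In this assay, 3-chlorophenyl in place of 2-chlorophenyl on the amide-type nitrogen again gives a step beyond the scatter on the second core, a 2.1-fold lower number from compound 3 to compound 4 (0.33 log units; beyond the scatter), and the step on the two cores points the same way and does not differ measurably in size: the same change on two cores in this assay, a 5.2-fold lower number (0.71 log units; beyond the scatter) from compound 1 to compound 2 and a 2.1-fold lower number (0.33 log units; beyond the scatter) from compound 3 to compound 4, 2.4-fold (0.39 log units) apart, within the scatter of two such steps Read the other way round, hydrogen in place of methyl on the aromatic carbon gives a 1.1-fold higher number from compound 2 to compound 4 (0.03 log units; within the scatter) with 3-chlorophenyl in the molecule, and this step likewise cannot be told apart from the one seen with 2-chlorophenyl: the same change on two cores in this assay, a 2.3-fold lower number (0.36 log units; beyond the scatter) from compound 1 to compound 3 and a 1.1-fold higher number (0.03 log units; within the scatter) from compound 2 to compound 4, 2.4-fold (0.39 log units) apart, within the scatter of two such steps The four compounds thus show that the change carries over in direction, but they rest on a single pair of steps on each side, so they show neither that its size is constant from core to core nor that it depends on the core.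

On these data alone, it remains open whether the same step would hold with 4-chlorophenyl, or with a methoxy group or a carboxylic acid in place of the chlorine. As far as these compounds go, it is equally open how the two cores would compare if an ethyl group stood in place of the methyl, or if the change were carried onto a core beyond these two.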